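The compounds below may be only part of what the source reports. "The series", "measured", "known", "first", "only" and "open" are said of these compounds alone.

Compound 1, `O=C(/C(=C\c1c(O)cc(O)cc1O)S(=O)(=O)c1ccccc1Br)c1ccc(Cl)cc1`, gives 50000 nM in a functional assay on DU-145 cells (Homo sapiens) for inhibition, read by trypan blue exclusion, with a stated time of 96 h; on this read-out higher numbers stand for weaker inhibition of growth and lower numbers for stronger inhibition of growth.
Compound 2, `Cc1ccc(S(=O)(=O)/C(=C/c2c(O)cc(O)cc2O)C(=O)c2ccc(Cl)cc2)cc1`, reaches > 100000 nM in this assay, which is a limit of the measurement and not a number.
Compound 3, `O=C(/C(=C\c1ccc(O)c([N+](=O)[O-])c1)Sc1ccccc1Br)c1ccc(Cl)cc1`, gives 25000 nM in this assay.

Compounds 1 and 2 share a core and differ in one place: 4-methylphenyl in place of 2-bromophenyl on a sulfonyl sulfur. That single exchange made a step of an at least 2.0-fold higher number from compound 1 to compound 2 (0.30 log units; that floor lies within the scatter). Only a floor for its size is known, because compound 2 sits at the limit of > 100000 nM in this assay, at which 1 of the 3 values shown sits.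

Compound 3 is built on a different core from compound 1; the difference between the two cores is not broken down here. Its value and the value of compound 1 lie within the usual scatter of each other, so no order between them can be read.

Compound 4, `Cc1ccc(S/C(=C/c2ccc(O)c([N+](=O)[O-])c2)C(=O)c2ccc(Cl)cc2)cc1`, has not yet been measured. Compared with compound 3 the change is 4-methylphenyl in place of 2-bromophenyl on a sulfur. Among the compounds with values here, this is the same kind of change as the one between compound 1 and compound 2, but not the same: there the new group sits on a sulfonyl sulfur whose other neighbours are a double-bonded chain carbon, here on a sulfur whose other neighbours are a double-bonded chain carbon.

In this assay compound 4 is expected to move by a 2.0-fold higher number from compound 3 to compound 4 (0.30 log units; within the scatter), a step in the same direction as the earlier one, an at least 2.0-fold higher number from compound 1 to compound 2 (0.30 log units; that floor lies within the scatter), which rests on that single comparison. Compound 4 is therefore estimated at 50000 nM, expected to fall between 20000 nM and 130000 nM.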

Compound 4, concentration for 50% growth inhibition: 10000 nM
The estimate for compound 4 lay 5.0-fold (0.70 log units) above the measured number; the whole stated range lies above it.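

On a sulfur, 4-methylphenyl in place of 2-bromophenyl gave a 2.5-fold lower number from compound 3 to compound 4 (0.40 log units; beyond the scatter) in this assay, and this step does not match the one seen for the same exchange on a sulfonyl sulfur: the same change on two cores in this assay, an at least 2.0-fold higher number (0.30 log units; that floor lies within the scatter) from compound 1 to compound 2 and a 2.5-fold lower number (0.40 log units; beyond the scatter) from compound 3 to compound 4, at least 5.0-fold (0.69 log units) apart, beyond the scatter of two such steps.
Compound 2 stands at a limit of the measurement and not at a number, so the earlier step is known only as a floor: the limit of > 100000 nM in this assay, at which 1 of the 4 values shown sits.
The exchange therefore cannot be carried from one of these cores to the other and be trusted to keep its direction, but with one pair on each core this shows no general rule, and it does not show which feature of the cores is responsible, since they differ in more than the state of the sulfur.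

The compounds shown leave open whether the new step comes from losing the bromine, from gaining the methyl, or from the different places these groups occupy on the ring, which 4-bromophenyl or 2-methylphenyl on the same sulfur could begin to separate. They also leave open how an amine or a carboxylic acid on that ring would behave, and whether either group would give the same result on both cores.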